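Hydroxypropyl to hydroxyethyl: compound 3 to compound 4

The source may hold more compounds than are shown below. What is called first, only, known or untested is meant among the compounds shown, and "the series" means these compounds.

Within the data shown here, compound 3 `COc1nc2ccc(Br)cc2cc1C(c1ccccc1)n1cc(CCCO)nn1` gives 14.7% in an ADME assay on PC-3 cells (Homo sapiens) for cytotoxicity, read by sulforhodamine B assay, with a stated time of 48 h, tested at 10 uM (on this read-out higher numbers stand for more inhibition at the one concentration tested (going by the name of the read-out) and lower numbers for less inhibition), the highest of the three numbers so far; compound 1 `COc1nc2ccc(Br)cc2cc1C(c1ccccc1)n1cc(-c2ccccc2)nn1` gives 5.97% and compound 2 `COc1nc2ccc(Br)cc2cc1C(c1ccccc1)n1cc(-c2ccccc2F)nn1` gives 13.4%. The steps of a number 8.7 percentage points higher from compound 1 to compound 3 (within the scatter) and a number 1.3 percentage points higher from compound 2 to compound 3 (within the scatter) both stay within the scatter, so compound 3 is not set apart from either. Compound 4 `COc1nc2ccc(Br)cc2cc1C(c1ccccc1)n1cc(CCO)nn1` differs from compound 3 by hydroxy in place of hydroxymethyl on a saturated chain carbon, two bonds along the chain from an aromatic carbon. Among the measured compounds shown here, no measured step trims this chain; the three steps on the shared core, including a number 7.4 percentage points higher from compound 1 to compound 2 (within the scatter), all remain within the scatter. Nothing therefore points to a step beyond the scatter in this assay for compound 4, and the expected change is a number 0.7 percentage points lower from compound 3 to compound 4 (within the scatter). Compound 4 is estimated at 14%, with a range from 4% to 24%.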

Compound 4, a percentage reported as inhibition, at one concentration (the size of the read-out at that concentration, not a potency): 15.5%
Compound 4: the middle estimate sits 1.5 percentage points below what was measured, and the stated range covers the measured number.
By their numbers in this assay, from the lowest: compounds 1, 2, 3 and 4 (each within the scatter of the next).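

In this assay, among these compounds, the chain itself is now varied for the first time, and a number 0.8 percentage points higher from compound 3 to compound 4 (within the scatter) shows that going from 3-hydroxypropyl to 2-hydroxyethyl does not separate the two compounds. Against the aromatic groups, 2-hydroxyethyl gives a number 2.1 percentage points higher from compound 2 to compound 4 (within the scatter) and a number 9.5 percentage points higher from compound 1 to compound 4 (within the scatter) and so, like 3-hydroxypropyl, is not set apart from either, leaving this position with no step beyond the scatter so far. No supporting measurement is available to explain these numbers.

Still open, from the compounds shown here alone, is whether a longer chain, an amine or a carboxylic acid in place of 2-hydroxyethyl would give a step beyond the scatter.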